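A few compounds are considered here, and "the series" means these few. Any claim that something is new, unique, unknown or untested is made for them only; others in the source may bear on it.

Three compounds have results in a functional assay on KYSE-450 cells (Homo sapiens) for inhibition, read by CCK-8 assay, with a stated time of 48 h; a higher number here means a weaker inhibitor, a lower number a stronger inhibitor. Compound 1 `COc1ccc(CN(C(=O)CSC(=S)N2CCCc3cc(C)ccc32)c2cc(OC)c(OC)c(OC)c2)cc1` gives 5210 nM, and compound 3 `COc1cc(N(Cc2ccc(Cl)cc2)C(=O)CSC(=S)N2CCN(C(=O)OC(C)(C)C)CC2)cc(OC)c1OC` gives 11900 nM, the higher of these two numbers and beyond the scatter from compound 1. Compound 2 `COc1ccc(CN(C(=O)CSC(=S)N2CCN(C(=O)OC(C)(C)C)CC2)c2ccccc2)cc1` reads > 20000 nM, which is a limit of the assay. Compound 4 `COc1ccc(CN(C(=O)CSC(=S)N2CCN(C(=O)OC(C)(C)C)CC2)c2cc(OC)c(OC)c(OC)c2)cc1C`, not yet measured, has 4-methoxy-3-methylphenyl in place of 4-chlorophenyl on a saturated chain carbon bound to an amide-type nitrogen. Within the data shown here, no measured pair isolates this change, so no shift beyond the scatter is expected in this assay, and the expectation stays anchored on compound 3 at 11900 nM. The expected step is a 1.3-fold lower number from compound 3 to compound 4 (0.12 log units; within the scatter). For compound 4 the estimated value is 9000 nM, with an expected range of 3500 nM to 20000 nM.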

Compound 4, half-maximal inhibitory concentration: > 20000 nM
Compound 4: a limit, no number (the forecaster's own chance of this, stated with the estimate: 15%); middle value at least 2.2-fold (0.34 log units) from the limit.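

In this assay, 4-methoxy-3-methylphenyl in place of 4-chlorophenyl on a saturated chain carbon bound to an amide-type nitrogen gives an at least 1.6-fold higher number from compound 3 to compound 4 (0.22 log units; that floor lies within the scatter). Among these compounds, this is the first direct reading of a change at this position, and it shows no gain over the 4-chlorophenyl of compound 3, though its floor alone does not establish a real loss. The true size of the step cannot be read because compound 4 sits at a limit of the assay: the limit of > 20000 nM in this assay, at which 2 of the 4 values shown sit.

Going by these compounds, whether 4-fluorophenyl or a pyridine ring at this position would give a lower number remains open. So does the effect of the same change on the core of compound 1.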